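The source may hold more compounds than are shown below. What is called first, only, known or untested is meant among the compounds shown, and "the series" means these compounds.

The measured compounds are:

compound 1, `COc1ccc(-c2cc(/C=C/C(=O)c3ccc(N)cc3)[nH]n2)cc1`: 4920 nM
compound 2, `COc1ccc(-c2cc(/C=C/C(=O)c3ccc(N)cc3)[nH]n2)cc1OC`: 7940 nM
compound 3, `COc1cc(C(=O)/C=C/c2cc(-c3cc(OC)c(OC)c(OC)c3)n[nH]2)cc(OC)c1OC`: 3120 nM

All three were tested in a functional assay on OVCAR-5 cells (Homo sapiens) for inhibition, read by sulforhodamine B assay, with a stated time of 48 h; a lower number here means a stronger inhibitor of growth, a higher number a weaker inhibitor of growth. Compound 2 and compound 1 differ in one place: hydrogen in place of methoxy on an aromatic carbon. That change gave a 1.6-fold lower number from compound 2 to compound 1 (0.21 log units; within the scatter). Compound 3 and compound 2 share the same general build but differ in several places, and the difference between the two cores is not broken down here; what their values show is that the number for compound 3 lies beyond the scatter from that of compound 2.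

Compound 4, `COc1ccc(-c2cc(/C=C/C(=O)c3cc(OC)c(OC)c(OC)c3)[nH]n2)cc1OC`, has not yet been tested in this assay. It differs from compound 3 by hydrogen in place of methoxy on an aromatic carbon. Within the data shown here, this is the same kind of change as the one from compound 2 to compound 1, though the place is not identical: in compound 3 the carbon that loses its methoxy is also meta to a methoxy group. The step of a 1.1-fold higher number from compound 3 to compound 4 (0.05 log units; within the scatter) is expected to stay small, because a 1.6-fold lower number from compound 2 to compound 1 (0.21 log units; within the scatter) was within the scatter. Compound 4 is therefore expected to give about 3500 nM, likely between 1600 nM and 8000 nM.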

Compound 4, concentration for total growth inhibition: 4310 nM
Compound 4: the middle estimate sits 1.2-fold (0.09 log units) below what was measured; the range from low to high includes it.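

In this assay, putting hydrogen in place of methoxy on an aromatic carbon gave a 1.4-fold higher number from compound 3 to compound 4 (0.14 log units; within the scatter). Set beside the earlier case, the two steps cannot be told apart, even though they run in opposite directions on paper: the same change on two cores in this assay, a 1.6-fold lower number (0.21 log units; within the scatter) from compound 2 to compound 1 and a 1.4-fold higher number (0.14 log units; within the scatter) from compound 3 to compound 4, 2.2-fold (0.35 log units) apart, within the scatter of two such steps. So on these two cores the swap moved the number by no more than the usual scatter of the assay, but two pairs cannot show that it would stay this small on any other core, and they cannot show that it truly has no effect or that its direction depends on the core.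

From the compounds shown here alone, only hydrogen has been seen in place of methoxy here, so it remains open whether a hydroxyl group, a chlorine atom or a longer chain such as ethoxy on the same carbon would shift the number beyond the scatter. The cores themselves differ in several places at once, which leaves the part played by the amine of compound 1 unresolved.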